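This account rests on a few compounds, and the source may have more. Where it says the series, first, only, none or still open, it means among the compounds named here.

Of the compounds shown here, three of a shared core have been tested in an ADME assay on Huh7.5.1 cells (Homo sapiens) for cytotoxicity, read by ATP content, with a stated time of 48 h; on this read-out lower numbers stand for higher toxicity in this test and higher numbers for lower toxicity in this test. Compound 1 `Cc1ccccc1-c1nc(CN2CCC(C(=O)NCCCN3[C@H](C)CCC[C@@H]3C)CC2)c(C)o1` gives 21300 nM in this assay. Compound 2 `Cc1oc(-c2c(Cl)cccc2Br)nc1CN1CCC(C(=O)NCCCN2C[C@H](C)C[C@H](C)C2)CC1` gives 12200 nM, and compound 3 `Cc1ccccc1-c1nc(CN2CCC(C(=O)N3CCN(CCN(C)C)CC3)CC2)c(C)o1` gives 27200 nM. Compound 2 therefore has the lowest of the three numbers, though the gap to compound 1 falls within the usual scatter of this assay, so no order can be claimed between those two; only the gap to compound 3 lies beyond the scatter.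

Compound 4 `COc1ccc(-c2nc(CN3CCC(C(=O)NCCCN4C[C@H](C)C[C@H](C)C4)CC3)c(C)o2)cc1OC` has not yet been measured in this assay. It differs from compound 2 in one place: 3,4-dimethoxyphenyl in place of 2-bromo-6-chlorophenyl on an aromatic carbon

Among the measured compounds shown here, no measured pair in this set isolates a change of this kind, so there is no directly comparable step to lean on. The three measured numbers all sit in a narrow band, and the change from a halogen-bearing ring to a methoxy-bearing one gives no firm reason to expect a large move. A small step in this assay from compound 2 to compound 4 is expected, a 1.6-fold higher number from compound 2 to compound 4 (0.21 log units; within the scatter), toward a somewhat higher number. Compound 4 is thus estimated at 20000 nM, with a range from 9000 nM to 45000 nM.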

Compound 4, half-maximal cytotoxic concentration: 57200 nM
The estimate for compound 4 lay 2.9-fold (0.46 log units) below the measured number, outside the stated range (above it).
By their numbers in this assay, from the lowest: compounds 2, 1 and 3 (each within the scatter of the next, the first and the last beyond it); then compound 4.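

In this assay the group on this aromatic carbon of the five-membered ring turns out to matter: with the rest of the molecule held fixed, 3,4-dimethoxyphenyl in place of 2-bromo-6-chlorophenyl gives a 4.7-fold higher number from compound 2 to compound 4 (0.67 log units; beyond the scatter). Among the compounds shown here, this is the first single change in the set that can be read on its own, and it lies beyond the usual scatter, moving toward lower toxicity in this test. Nothing available accounts for the size or direction of this step.

The swap removes bromine and chlorine and adds two methoxy groups at once, so the compounds shown cannot say which part of it carries the step; an unsubstituted phenyl ring or a ring with a single methoxy group would help separate these. On these data alone, whether the same swap has a similar effect on a different side chain also remains open.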